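A few compounds are considered here, and "the series" means these few. Any claim that something is new, unique, unknown or untested is made for them only; others in the source may bear on it.

Measured compounds:
compound 1 `Cc1ccc(-c2cc(Cl)cc(C(=O)Nc3nn[nH]n3)n2)cc1` gives 86%
compound 2 `Nc1ccc(-c2cc(Cl)cc(C(=O)Nc3nn[nH]n3)n2)cc1` gives 100%
compound 3 `CCOc1cc(C(=O)Nc2nn[nH]n2)nc(-c2ccc(C)cc2)c1` gives 65%

In a functional assay on the whole organism with Rattus norvegicus as the target, at a dose of 1 mg/kg by the oral route (a higher number here means a stronger effect of the compound at the dose given, a lower number a weaker effect), compound 3 stands lowest of the three numbers; compound 1 sits a number 21 percentage points lower from compound 1 to compound 3 (beyond the scatter) reversed in sense, and compound 2 lies furthest from it. Among the compounds with values here, the only change within the measured set that touches the same position is the one from compound 1 to compound 2, a number 14 percentage points higher from compound 1 to compound 2 (beyond the scatter), a modest gain beyond the scatter. Compound 4 `CCOc1cc(C(=O)Nc2nn[nH]n2)nc(-c2ccc(N)cc2)c1` differs from compound 3 by amino in place of methyl on an aromatic carbon. On that single precedent a gain of similar size is expected, that is a number 14 percentage points higher from compound 3 to compound 4 (beyond the scatter). Within the data shown here, for compound 4 the estimated read-out in this assay is 79%, with a range from 62% to 93%; only one supporting step exists, so the range is kept wide.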

Compound 4, a percentage reported as inhibition, in the whole organism at one dose (the size of the read-out at that dose, not a potency): 52%
Estimate against measurement, compound 4: 27 percentage points above; the whole stated range lies above it.
By their numbers in this assay, from the lowest: compound 4; then compound 3; then compound 1; then compound 2.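

In this assay the change from 4-methylphenyl to 4-aminophenyl has no fixed direction, and its outcome differs between the chloro and ethoxy cores: the same change on two cores in this assay, a number 14 percentage points higher (beyond the scatter) from compound 1 to compound 2 and a number 13 percentage points lower (beyond the scatter) from compound 3 to compound 4, 27 percentage points apart, beyond the scatter of two such steps
On the ethoxy core, the amino compound falls below its methyl partner (a number 13 percentage points lower from compound 3 to compound 4 (beyond the scatter)). Ethoxy in place of chloro also costs more with 4-aminophenyl (a number 48 percentage points lower from compound 2 to compound 4 (beyond the scatter)) than with 4-methylphenyl, so the two changes do not simply add: the same change on two cores in this assay, a number 21 percentage points lower (beyond the scatter) from compound 1 to compound 3 and a number 48 percentage points lower (beyond the scatter) from compound 2 to compound 4, 27 percentage points apart, beyond the scatter of two such steps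
Only chloro and ethoxy are shown at this place, so it remains open whether the reversal is specific to ethoxy. Methoxy or a longer alkoxy chain, paired with both methyl and amino, would test this.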